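Swapping the Sulfonyl Substituent of Compound 1

The compounds below may be only part of what the source reports. "The series", "measured", "known", "first", "only" and "open" are said of these compounds alone.

Among the compounds with values here, in an ADME assay on microsomes from liver (Rattus norvegicus) for metabolic stability, read by LC-MS, using NADPH, with a stated time of 30 min, tested at 0.1 uM (a lower number here means that less of the compound is left, a higher number that more of the compound is left), compound 1 `O=S(=O)(c1cccc(-c2ccc3nccc(-c4ccncc4)c3n2)c1)N1CCC(O)CC1` gives 11% as the lower of the two numbers measured so far. Compound 2 `NS(=O)(=O)c1ccc(-c2ccc3nccc(-c4ccncc4)c3n2)cc1` gives 36% in this assay and so stands above compound 1 by a margin beyond the usual scatter. Compound 3 `C[C@@H]1CN(S(=O)(=O)c2cccc(-c3ccc4nccc(-c5ccncc5)c4n3)c2)C[C@H](C)N1` carries 3,5-dimethylpiperazin-1-yl in place of 4-hydroxypiperidin-1-yl on a sulfonyl sulfur and otherwise keeps the core of compound 1. Within the data shown here, no measured pair shows what such an exchange does, so only a small rise is expected, and not one clearly beyond the scatter. The expected step of a number 9 percentage points higher from compound 1 to compound 3 (within the scatter) would leave compound 3 still low on this read-out. For compound 3 the estimated value is 20% with 6% to 45% as the expected range.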

Compound 3, percent of the compound remaining: 36%
Compound 3: middle estimate off by 16 percentage points, on the low side, within the range that was stated.
By their numbers in this assay, from the lowest: compound 1; then compounds 2 and 3 (each within the scatter of the next).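

At the sulfonyl sulfur whose other neighbour is an aromatic carbon, this assay gives the first measured exchange: 3,5-dimethylpiperazin-1-yl in place of 4-hydroxypiperidin-1-yl reads a number 25 percentage points higher from compound 1 to compound 3 (beyond the scatter), a modest step. The group on this sulfur therefore changes how much compound is left, and with the core of compound 1 held constant, more remains with the new group. Nothing at hand gives a reason for this step.

The compounds shown leave open whether an unsubstituted piperazin-1-yl would give a similar step or whether the two methyl groups and their defined stereocentres are needed. They also leave open how morpholin-4-yl or an open-chain amine would stand on the same sulfonyl sulfur.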